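Replacing the urea on the piperazine of compound 1

The source may hold more compounds than are shown below. What is called first, only, known or untested is meant among the compounds shown, and "the series" means these compounds.

Among the measured compounds shown here, compound 1 `COc1ccc(-c2cnc3nc(N)nc(N4CCN(C(=O)Nc5ccc(C)cc5)CC4)c3n2)cc1OC` is the stronger of the two compounds measured so far. In a functional assay on cells (T-cell, Homo sapiens) for inhibition (a higher number here means a weaker inhibitor, a lower number a stronger inhibitor), compound 1 gives 0.8 nM. For the measured compounds named here, compound 2 `COc1ccc(-c2cnc3nc(N)nc(NCc4ccccc4)c3n2)cc1OC` carries a benzylamine directly on the shared core instead of the substituted piperazine, and in this assay compound 2 gives 13000 nM, a much weaker result; the two structures differ in more than one place, so no single step can be drawn between them.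

Compound 3 `COc1ccc(-c2cnc3nc(N)nc(N4CCN(Cc5ccc(C(C)(C)C)cc5)CC4)c3n2)cc1OC` keeps the piperazine of compound 1 but changes the group on its ring nitrogen: 4-(tert-butyl)benzyl in place of (4-methylphenyl)carbamoyl on an amine nitrogen in a ring. Going by the values given here, no measured pair shows this kind of change, so the expectation rests on the size of the gap that separates compound 1 from compound 2 and on the loss of the carbamoyl group. Compound 3 is expected to remain clearly stronger than compound 2 while falling short of compound 1, with an estimated step of a 130-fold higher number from compound 1 to compound 3 (2.10 log units; beyond the scatter) toward weaker inhibition. In this assay compound 3 is estimated at 100 nM, with a range from 10 nM to 1000 nM.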

Compound 3, half-maximal inhibitory concentration: 4300 nM
Beside the measured number, compound 3's estimate is 43-fold (1.63 log units) below it; measured number outside the range, above it.
By their numbers in this assay, from the lowest: compound 1; then compound 3; then compound 2.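

In this assay the exchange of (4-methylphenyl)carbamoyl for 4-(tert-butyl)benzyl on the ring nitrogen of the piperazine gives a 5400-fold higher number from compound 1 to compound 3 (3.73 log units; beyond the scatter) and so shows, as compound 1 and compound 2 could not, that this position is highly sensitive to the group it carries. A six-membered aromatic ring of carbon only stands on both sides of the change, so such a ring on this nitrogen is not enough by itself to keep the low number of compound 1, although the carbonyl, the hydrogen-bond donor and the hydrogen-bond acceptor all leave in the same step. Nothing measured here accounts for the size of this step.

The compounds shown do not separate the loss of the carbamoyl link from the exchange of methyl for tert-butyl on the aromatic ring, since both happen together in this one step. A 4-methylbenzyl group or a (4-(tert-butyl)phenyl)carbamoyl group on the same nitrogen would change only one of the two, and a 4-methylbenzoyl group would keep the carbonyl while removing the amide hydrogen.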